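The compounds below may be only part of what the source reports. "The series", "measured", "known", "first", "only" and "open" are said of these compounds alone.

Two compounds of this study share one core and differ only in the chain on the aromatic nitrogen. Compound 1 `Cn1nc(Cc2nnc(SCC(=O)Nc3ccc(Cl)cc3Cl)n2CCCO)c2ccccc2c1=O` carries a hydroxypropyl chain, and in an assay on NK92 cells for inhibition of interleukin-2 (Homo sapiens), read by AlphaScreen, with stated times of 30 min and 1 h (on this read-out higher numbers stand for weaker inhibition and lower numbers for stronger inhibition), compound 1 gives > 30000 nM, which is a limit of the assay rather than a number. Compound 2 `Cn1c(Cc2nn(CCC3OCCO3)c(=O)c3ccccc23)nnc1SCC(=O)Nc1ccc(Cl)cc1Cl` carries the 2-(1,3-dioxolan-2-yl)ethyl chain, and in this assay compound 2 gives > 30000 nM, again a limit and not a number. Both values therefore sit at the limit of > 30000 nM in this assay, at which 2 of the 2 values shown sit, and neither compound gives a measured figure. Compound 3 `Cn1c(Cc2nn(CCC(=O)O)c(=O)c3ccccc23)nnc1SCC(=O)Nc1ccc(Cl)cc1Cl` has not yet been measured; it differs from compound 2 by carboxy in place of 1,3-dioxolan-2-yl on a saturated chain carbon, two bonds along the chain from an aromatic nitrogen, so the chain becomes 2-carboxyethyl. Among the compounds with values here, with no measured step to guide the size, compound 3 is expected to stay at the limit as well, the estimated step from compound 2 being a number no higher from compound 2 to compound 3 (the limit leaves the size open). The estimate for compound 3 in this assay is 30000 nM, within a range from 8000 nM to 150000 nM.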

Compound 3, half-maximal inhibitory concentration: > 30000 nM
Compound 3 ended at the assay's limit (the forecaster's own chance of this, stated with the estimate: 80%); the middle value sits exactly at the limit.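

No step can be read from compound 2 to compound 3, because both values are limits of the assay and not numbers in this assay: the limit of > 30000 nM in this assay, at which 3 of the 3 values shown sit.

The compounds shown leave open how the 2-(1,3-dioxolan-2-yl)ethyl and 2-carboxyethyl chains compare, and what on the shared core would give a measured figure in this assay.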